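A chlorophenyl for butoxyphenyl in a weakly antiproliferative series

The source may hold more compounds than are shown below. What is called first, only, known or untested is meant among the compounds shown, and "the series" means these compounds.

Compound 1 `Cc1cccc(NNC(=O)c2ccc(NS(=O)(=O)c3cnc(O)nc3O)cc2)c1` (> 20000 nM, a limit)
Compound 2 `O=C(NNc1ccccc1Cl)c1ccc(NS(=O)(=O)c2cnc(O)nc2O)cc1` (7230 nM)
Compound 3 `CCCCOc1ccc(C(=O)NNC(=O)c2ccc(NS(=O)(=O)c3cnc(O)nc3O)cc2)cc1` (12800 nM)

All three were tested in a functional assay on OVCAR-3 cells (Homo sapiens) for antiproliferative activity, read by MTT assay, with a stated time of 24 h (on this read-out higher numbers stand for weaker inhibition and lower numbers for stronger inhibition), and the entry for compound 1 is a limit, not a number. Compound 3 (12800 nM) lies within the scatter of compound 2 (7230 nM). Compound 4 `O=C(NNC(=O)c1cccc(Cl)c1)c1ccc(NS(=O)(=O)c2cnc(O)nc2O)cc1` has yet to be measured in this assay and differs from compound 3 thus: 3-chlorophenyl in place of 4-butoxyphenyl on a carbonyl carbon.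

Going by the values given here, only one measured step bears on this change, and only indirectly: an at least 2.7-fold lower number from compound 1 to compound 2 (0.44 log units; beyond the scatter) (beyond the scatter) put 2-chlorophenyl in place of 3-methylphenyl on an amine nitrogen, not on a carbonyl carbon. Compound 2 (7230 nM) also carries a chlorophenyl, so a slightly lower number is expected, though nothing beyond the scatter. The estimated move is a 1.3-fold lower number from compound 3 to compound 4 (0.11 log units; within the scatter) and no larger. The estimate for compound 4 is 10000 nM (4500 nM to 20000 nM), an expected value only.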

Compound 4, half-maximal inhibitory concentration: 7710 nM
Estimate against measurement, compound 4: 1.3-fold (0.11 log units) above; the measured number falls inside the stated range.
By their numbers in this assay, from the lowest: compounds 2, 4 and 3 (each within the scatter of the next). At a limit, above all of these: compound 1.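

The 4-butoxyphenyl on the carbonyl carbon is not needed for this level of antiproliferative activity: 3-chlorophenyl, with fewer heavy atoms and no hydrogen-bond acceptor, gives a result within the scatter (a 1.7-fold lower number from compound 3 to compound 4 (0.22 log units; within the scatter)). The aryl group can also be carried as (3-chlorophenyl)carbonyl instead of 2-chlorophenyl on an amine nitrogen, again without leaving the scatter (a 1.1-fold higher number from compound 2 to compound 4 (0.03 log units; within the scatter)). Against 3-methylphenyl on that nitrogen the same change gives a step beyond the scatter (an at least 2.5-fold lower number from compound 1 to compound 4 (0.41 log units; beyond the scatter)), though this step is only a bound, as compound 1 stands at a limit: the limit of > 20000 nM in this assay, at which 1 of the 4 values shown sits.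

The compounds shown leave open whether an unsubstituted phenyl, a 4-chlorophenyl or a 4-methoxyphenyl on this carbonyl carbon would stay within the scatter. They also leave open whether a carboxylic acid or an amine on that ring would move the number beyond it.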